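Removing an Acetyl Group: From Compound 1 to Compound 4

The source may hold more compounds than are shown below. What is called first, only, known or untested is meant among the compounds shown, and "the series" means these compounds.

Compound 1 `CC(=O)OCCO[C@H](CC=C(C)C)C1=CC(=O)c2c(O)ccc(O)c2C1=O`: 41500 nM
Compound 2 `CCCC(CC(=O)O[C@H](CC=C(C)C)C1=CC(=O)c2c(O)ccc(O)c2C1=O)OC(C)=O`: 51200 nM
Compound 3 `CC(C)=CC[C@@H](OC(=O)CC(O)c1ccccc1)C1=CC(=O)c2c(O)ccc(O)c2C1=O`: 44500 nM

In a functional assay on HeLa cells (Homo sapiens) for cytotoxicity, read by MTT assay (a lower number here means a stronger inhibitor, a higher number a weaker inhibitor), compound 1 gives 41500 nM, the lowest of the three numbers, yet its gaps to compound 3 and to compound 2 both lie within the scatter, so none of the three can be set apart from the others. Compound 4 `CC(C)=CC[C@@H](OCCO)C1=CC(=O)c2c(O)ccc(O)c2C1=O` has not yet been measured. It differs from compound 1 in one place: hydrogen in place of acetyl on an oxygen on a saturated carbon. Among the compounds with values here, only one measured step is available for comparison, a 1.2-fold lower number from compound 2 to compound 3 (0.06 log units; within the scatter), which exchanged one ester side chain for another and left the number within the scatter. That step does not remove an acetyl from an oxygen as here, so it bears on the present change only loosely, but the one measured alteration in that part of the molecule did not move this assay. No step beyond the scatter is therefore expected, and the step from compound 1 to compound 4 is estimated as a 1.0-fold higher number from compound 1 to compound 4 (0.01 log units; within the scatter). Compound 4 is expected to give about 42000 nM, within a range from 15000 nM to 120000 nM.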

Compound 4, half-maximal inhibitory concentration: 18600 nM
Estimate against measurement, compound 4: 2.3-fold (0.35 log units) above, within the range that was stated.
By their numbers in this assay, from the lowest: compound 4; then compounds 1, 3 and 2 (each within the scatter of the next).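

In this assay, hydrogen in place of acetyl on the oxygen of the 2-acetoxyethyl chain gives a 2.2-fold lower number from compound 1 to compound 4 (0.35 log units; beyond the scatter), a modest step but the only one here that lies beyond the scatter. The earlier compounds shown here offered a single comparison, an exchange of one ester side chain for another, and it did not move the number; this result shows that the number can respond to a change in a side chain on the shared core. Nothing available here explains why the 2-hydroxyethyl chain gives the lower number.

Going by these compounds, it remains open whether the hydroxy group itself matters or only the loss of the acetyl does. A methoxy group, an amine or a carboxylic acid at that chain end, or a longer chain ending in hydroxy, would help to separate these two readings.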